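The source may report more compounds than this note shows. Statements on the series, on what has been measured and on what is new or still open speak of the compounds shown alone.

Measured in a functional assay on Raji cells (Homo sapiens) for cytotoxicity, with a stated time of 72 h; on this read-out higher numbers stand for weaker inhibition and lower numbers for stronger inhibition:
compound 1 (`CCOC(=O)/C=C/C=C/C=C/c1ccc[nH]1`) gives > 10000 nM (a limit of the assay, not a number)
compound 2 (`CCOC(=O)/C=C/C=C/C=C/c1nccs1`) gives 4350 nM

Going by the values given here, compound 2 gives 4350 nM as the only exact number so far. Compound 1 stands at the limit of > 10000 nM in this assay, at which 1 of the 2 values shown sits, and has no exact number.

The next compound, compound 3 (`CCOC(=O)/C=C/C=C/C=C/c1ccco1`), changes one group: furan-2-yl in place of 1,3-thiazol-2-yl on a double-bonded chain carbon bound to a double-bonded chain carbon and the rest of the molecule stays the same.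

Among the compounds with values here, only one measured step bears on this change. That step, an at least 2.2-fold lower number from compound 1 to compound 2 (0.36 log units; beyond the scatter), came with 1,3-thiazol-2-yl taking the place of 1H-pyrrol-2-yl, so swapping one five-membered aromatic ring for another can move the number. It is a single step, however, and furan-2-yl played no part in it, so it sets no direct size for the new change.

Starting from compound 2 and its 4350 nM, compound 3 is expected to shift only a little, towards a somewhat higher number, and probably not clearly beyond the scatter. The expected change is a 1.4-fold higher number from compound 2 to compound 3 (0.14 log units; within the scatter) in this assay. For compound 3 the estimated value is 6000 nM, with an expected range from 2200 nM to 14000 nM as its ends.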

Compound 3, half-maximal inhibitory concentration: > 10000 nM
Compound 3: only a limit was reported (the forecaster's own chance of this, stated with the estimate: 35%); middle value at least 1.6-fold (0.22 log units) from the limit.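

In this assay compound 3 gives > 10000 nM, which is a limit of the assay and not a number. On a double-bonded chain carbon bound to a double-bonded chain carbon, furan-2-yl in place of 1,3-thiazol-2-yl brings an at least 2.2-fold higher number from compound 2 to compound 3 (0.36 log units; beyond the scatter), so this exchange of one five-membered aromatic ring for another, with the same count of 5 heavy atoms, moves the read-out beyond the scatter. Compound 2 now stands out as the only one of the three with an exact number, while the step between compound 1 and compound 3 cannot be read, and the measured values show how few of them can be placed exactly: the limit of > 10000 nM in this assay, at which 2 of the 3 values shown sit.

Going by these compounds, how far compound 1 and compound 3 lie past that limit remains unknown, so these two cannot be ranked against each other. On these data alone, it also remains open whether a phenyl group or an amine at this place would give a lower number than compound 2, a similar one or a higher one, and so whether 1,3-thiazol-2-yl is unusual here or merely one of several workable groups.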